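The source may report more compounds than this note shows. Statements on the series, on what has been measured and on what is new or still open speak of the compounds shown alone.

Measured so far in a functional assay on KB cells (Homo sapiens) for inhibition; on this read-out lower numbers stand for stronger inhibition and higher numbers for weaker inhibition:
Compound 1, `Nc1nc2cc(Cl)c(Cl)cc2n1COCCO`, gives a limit: > 100000 nM.
Compound 2, `OCCOCn1cnc2cc(Cl)c(Cl)cc21`, gives a limit: > 100000 nM.
Compound 3, `OCCOCn1c(S)nc2cc(Cl)c(Cl)cc21`, gives a limit: > 100000 nM.

Each of these three readings is a limit of the measurement rather than a number, so none of the three compounds shows inhibition that could be pinned down. Compound 3 therefore stands at the limit of > 100000 nM in this assay, at which 3 of the 3 values shown sit. Its place among the others cannot be ranked, since all three readings coincide at that limit.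

Compound 4, `OCCOCn1c(Br)nc2cc(Cl)c(Cl)cc21`, is not yet measured. It differs from compound 3 in one place: bromo in place of sulfanyl on an aromatic carbon. Among the measured compounds shown here, none of the measured steps involves a bromo group, so the closest guides are the steps that swap groups on an aromatic carbon of the shared core: a step that the two limits leave unreadable from compound 1 to compound 2, a step that the two limits leave unreadable from compound 1 to compound 3 and a step that the two limits leave unreadable from compound 2 to compound 3. Each of them runs from one limit to another, so their sizes cannot be read. With amino, hydrogen and sulfanyl all failing to give a measurable value, no step beyond the scatter can be foreseen for compound 4 in this assay, and a limit is expected once more. Compound 4 is estimated at 200000 nM, with a range from 30000 nM to 1000000 nM, which means an expected step that the limit leaves unreadable from compound 3 to compound 4.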

Compound 4, half-maximal inhibitory concentration: > 100000 nM
Compound 4: a limit, no number; the forecaster's own chance of this, stated with the estimate: 85%; the middle value is on the limit's open side.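

In this assay compound 4 gives a limit and not a number, like compound 1, compound 2 and compound 3, so no step among these four compounds can be read: the limit of > 100000 nM in this assay, at which 4 of the 4 values shown sit.

The compounds shown leave open whether amino, hydrogen, sulfanyl and bromo on this aromatic carbon of the shared core differ in inhibition at all.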